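Compound 4: Trifluoromethyl in Place of a Larger Group

The compounds below may be only part of what the source reports. "The series", "measured", "known", "first", "only" and "open" are said of these compounds alone.

Compound 1 `O=C(Nc1ccnnc1)c1cc(N2CCNCC2)ccc1OCc1ccccc1`: 15.9 nM
Compound 2 `O=C(Nc1ccnnc1)c1cc(N2CCCC2)ccc1OCc1ccccc1`: 20 nM
Compound 3 `CN1CC2(CCN(c3ccc(OCc4ccccc4)c(C(=O)Nc4ccnnc4)c3)CC2)C1`: 63.1 nM

In an assay on Sf9 cells for inhibition of Leucine-rich repeat serine/threonine-protein kinase 2 (Homo sapiens), read by TR-FRET, with stated times of 30 min and 2 h (a higher number here means a weaker inhibitor, a lower number a stronger inhibitor), compound 3 gives the highest of the three numbers. Its nearest neighbour is compound 2, with a 3.2-fold higher number from compound 2 to compound 3 (0.50 log units; beyond the scatter), and the step of a 4.0-fold higher number from compound 1 to compound 3 (0.60 log units; beyond the scatter) is a little larger; both lie beyond the scatter, so compound 3 is the weakest of the three. The step of a 1.3-fold higher number from compound 1 to compound 2 (0.10 log units; within the scatter), by contrast, lies within the scatter.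

Compound 4 `O=C(Nc1ccnnc1)c1cc(C(F)(F)F)ccc1OCc1ccccc1` is obtained from compound 3 by the change a group of 4 heavy atoms (1 carbon, 3 fluorine; no ring) in place of a group of 10 heavy atoms (8 carbon, 2 nitrogen; one four-membered non-aromatic ring with 1 hetero atom, one six-membered non-aromatic ring with 1 hetero atom), on an aromatic carbon

Going by the values given here, no measured step bears directly on this change: every step so far exchanges one ring-bearing nitrogen group for another, whereas here a trifluoromethyl group with no ring and no nitrogen enters. The two steps ending in compound 3 show that this position tolerates variation in the modest range, and the step from compound 1 to compound 2 shows that some exchanges there pass without effect. Compound 4 is therefore expected to stay near compound 3, with the step of a 1.3-fold higher number from compound 3 to compound 4 (0.10 log units; within the scatter), though the range is set wide. The estimate for compound 4 in this assay is 80 nM, between 20 nM and 320 nM.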

Compound 4, half-maximal inhibitory concentration: 15.9 nM
Estimate against measurement, compound 4: 5.0-fold (0.70 log units) above; measured number outside the range, below it.
By their numbers in this assay, from the lowest: compounds 1, 4 and 2 (each within the scatter of the next); then compound 3.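

In this assay the group on this aromatic carbon, para to a benzyloxy group, need not hold a ring or a nitrogen: trifluoromethyl, with no ring and no hydrogen-bond acceptors, reads level with both smaller nitrogen rings, showing no change at the digits printed from compound 1 to compound 4 (within the scatter) against piperazin-1-yl and a 1.3-fold lower number from compound 2 to compound 4 (0.10 log units; within the scatter) against pyrrolidin-1-yl. The earlier steps compared only ring-bearing nitrogen groups, whereas the new step, a 4.0-fold lower number from compound 3 to compound 4 (0.60 log units; beyond the scatter) in exchange for the group of 10 heavy atoms, shows that the higher number of compound 3 is not shared by a group of an entirely different kind, so among these four compounds that group alone stands apart. Nothing available here explains why three such different groups read alike.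

From the compounds shown here alone, it remains open whether the same level reading would hold for a single fluorine, a nitrile, a carboxylic acid or an open-chain amine on this carbon. The compounds shown also leave open whether a piperazin-1-yl ring carrying a longer chain on its free nitrogen would read with compound 1 or with compound 3.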